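Adding methoxy to compound 3

The source may report more compounds than this note shows. Statements on the series, on what has been measured and on what is new or still open speak of the compounds shown alone.

Measured in a functional assay on CUTLL1 cells (Homo sapiens) for inhibition, read by resazurin assay, with a stated time of 48 h, in the presence of a further agent that is not named here; on this read-out higher numbers stand for an effect only at larger amounts of compound and lower numbers for an effect already at smaller amounts:
Compound 1 `Nc1ncc(-c2cccnc2)c(C2CC2)n1`: > 100000 nM (a limit)
Compound 2 `Nc1ncc(-c2ccnc3ccccc23)c(C2CC2)n1`: > 100000 nM (a limit)
Compound 3 `Nc1ncc(-c2ccccc2)c(C2CC2)n1`: > 100000 nM (a limit)

Compound 3 gives no number to work from. Its reading of > 100000 nM is a limit of the assay and not a measured potency. The same is true across the whole set, which shows (the limit of > 100000 nM in this assay, at which 3 of the 3 values shown sit).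

The next compound, compound 4 `COc1ccc(-c2cnc(N)nc2C2CC2)cc1`, keeps the shared core of compound 3. It carries methoxy in place of hydrogen on an aromatic carbon, para to a large group: methoxy in place of hydrogen on an aromatic carbon.

Going by the values given here, no pair of measured compounds yields a step in this assay, so the size of this change cannot be read from the data. Compounds 1, 2 and 3 differ in their aromatic group, yet none of them leaves the limit. On that basis, no step beyond the usual scatter is expected. Any visible change could only run towards smaller amounts of compound, and another reading at the limit is the likeliest outcome.

The estimated change is a number no higher from compound 3 to compound 4 (the limit leaves the size open).

For compound 4 the expected value is 100000 nM, with an estimated range from 25000 nM to 150000 nM.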

Compound 4, half-maximal effective concentration: > 100000 nM
Compound 4 gave a limit, no number (the forecaster's own chance of this, stated with the estimate: 75%); the middle value lies on the limit itself.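

In this assay compound 4 gives > 100000 nM, which is a limit and not a number. Compound 3 also stands at a limit, so no step can be read between compound 3 and compound 4. The compounds shown leave open what methoxy does to the effect in this assay, and whether any of them reaches a measurable value, since the set offers only this: the limit of > 100000 nM in this assay, at which 4 of the 4 values shown sit.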